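The source may hold more compounds than are shown below. What is called first, only, known or untested is meant among the compounds shown, and "the series" means these compounds.

Compound 1 `Oc1ccc(-c2cc(-c3ccoc3)cc(-c3ccccc3O)n2)cc1`: > 50000 nM
Compound 2 `Oc1ccc(-c2cc(-c3ccoc3)cc(-c3cccc(O)c3)n2)cc1`: 2610 nM
Compound 3 `Oc1ccc(-c2cc(-c3ccoc3)cc(-c3ccc(O)cc3)n2)cc1`: 3460 nM

Three compounds share one core and differ only in where the hydroxyl sits on one of the phenyl rings. In a functional assay on T47D cells (Homo sapiens) for cytotoxicity, read by CCK-8 assay (a higher number here means a weaker inhibitor, a lower number a stronger inhibitor), compound 1 gives > 50000 nM, which is a limit of the assay rather than a number (the limit of > 50000 nM in this assay, at which 1 of the 3 values shown sits). Compound 2 gives 2610 nM in this assay, and compound 3 gives 3460 nM. Moving the hydroxyl changed a great deal: an at least 19-fold lower number from compound 1 to compound 2 (1.28 log units; beyond the scatter), and an at least 14-fold lower number from compound 1 to compound 3 (1.15 log units; beyond the scatter). Between the two numbers, a 1.3-fold higher number from compound 2 to compound 3 (0.12 log units; within the scatter), so compound 3 holds the higher of the two numbers while standing within the scatter of compound 2.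

Compound 4 `Oc1ccc(-c2cc(-c3ccccn3)cc(-c3ccc(O)cc3)n2)cc1` keeps both 4-hydroxyphenyl groups of compound 3 and alters the remaining ring instead: pyridin-2-yl in place of furan-3-yl on an aromatic carbon. Among the measured compounds shown here, none of the measured steps touches this position; all three swap one hydroxyphenyl for another, so they give no direct guide to this exchange. With nothing to carry over, the expectation is that the step from compound 3 to compound 4 stays within the scatter: a 1.0-fold higher number from compound 3 to compound 4 (0.00 log units; within the scatter). Compound 4 is therefore estimated at 3500 nM in this assay, with a range from 1200 nM to 10000 nM.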

Compound 4, half-maximal inhibitory concentration: 1040 nM
Compound 4: middle estimate off by 3.4-fold (0.53 log units), on the high side; measured number outside the range, below it.
By their numbers in this assay, from the lowest: compound 4; then compounds 2 and 3 (each within the scatter of the next). At a limit, above all of these: compound 1.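

In this assay, the ring opposite the ring nitrogen proves to be a position that matters: with both 4-hydroxyphenyl groups held fixed, pyridin-2-yl in place of furan-3-yl gives a 3.3-fold lower number from compound 3 to compound 4 (0.52 log units; beyond the scatter). Among the compounds shown here, the earlier steps only moved a hydroxyl around a phenyl ring, so this is the first sign that the number also responds to a change at this separate position, although the step is a modest one. The exchange replaces a five-membered aromatic ring holding oxygen with a six-membered aromatic ring holding nitrogen, and nothing measured here explains why the number moves.

On these data alone, a single exchange cannot separate ring size from the identity of the hetero atom, so it remains open what a plain phenyl, a pyridin-3-yl or a small amine at this position would do. As far as these compounds go, it is also open whether pyridin-2-yl would give a similar step when the 3-hydroxyphenyl group of compound 2 is present, or whether this step depends on the pair of 4-hydroxyphenyl groups.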